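Chloro substitution on the lactam ring of compound 2

This account rests on a few compounds, and the source may have more. Where it says the series, first, only, none or still open, it means among the compounds named here.

Measured compounds in a functional assay on cells (Cancer cell lines, Homo sapiens) for cytotoxicity, with a stated time of 48 h; on this read-out lower numbers stand for stronger inhibition of growth and higher numbers for weaker inhibition of growth:
- compound 1 `O=C1/C(=C/c2c(Cl)[nH]c3ccccc23)c2ccccc2N1Cc1ccccc1` gives 6170 nM
- compound 2 `COc1c(/C=C2/C(=O)Nc3ccccc32)c2ccccc2n1-c1ccccc1` gives 1120 nM
- compound 3 `COc1cc2c(cc1C)NC(=O)/C2=C/c1c(Cl)n(Cc2cc(OC)c(OC)c(OC)c2)c2cc(C)c(OC)cc12` gives 5500 nM

Compound 2 stands lowest of the three numbers in this assay; compound 3 is nearest to it and compound 1 furthest, and both gaps lie beyond the scatter, so compound 2 is the strongest growth inhibitor measured so far.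

Compound 4 `COc1c(/C=C2/C(=O)Nc3ccc(Cl)cc32)c2ccccc2n1-c1ccccc1` is not yet measured. It differs from compound 2 by chloro in place of hydrogen on an aromatic carbon. Among the compounds with values here, no pair of measured compounds shows this change, so nothing measured here tells its size. The expected step from compound 2 to compound 4 in this assay is a 1.2-fold lower number from compound 2 to compound 4 (0.09 log units; within the scatter), within the scatter. Compound 4 is therefore estimated at 900 nM, in the range 300 nM to 2700 nM.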

Compound 4, concentration for 50% growth inhibition: 9330 nM
Estimate against measurement, compound 4: 10-fold (1.02 log units) below, and the stated range ends below it.
By their numbers in this assay, from the lowest: compound 2; then compounds 3, 1 and 4 (each within the scatter of the next).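

In this assay, within the data shown here, chloro in place of hydrogen on this aromatic carbon gives an 8.3-fold higher number from compound 2 to compound 4 (0.92 log units; beyond the scatter) and is the first single-place change that can be read. The position, on the six-membered aromatic ring of carbon only, is thus sensitive to substitution: one added chlorine atom is enough for a step beyond the scatter. No measurement here bears on the cause of this step.

As far as these compounds go, whether a fluoro group or an amine on the same carbon would hold the number of compound 2 remains open. Also open, from the compounds shown here alone, is whether chloro on another carbon of this ring would give a step of similar size.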